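The compounds below may be only part of what the source reports. "The series", "measured", "known", "first", "only" and "open" are said of these compounds alone.

Of the compounds shown here, three have been measured so far in a functional assay on NCI-H460 cells (Homo sapiens) for cytotoxicity, read by MTT assay, with a stated time of 68 h; on this read-out lower numbers stand for stronger inhibition and higher numbers for weaker inhibition. Within the data shown here, compound 1 `CCOc1ccccc1-c1cc(NC(=O)C(Cl)Cl)cc(-c2ccccc2OCC)c1` gives 5090 nM, the only true number among them. Compound 2 `O=C(Nc1cccc(-c2cccs2)c1)C(Cl)Cl` shows only a limit of the assay, > 50000 nM. Compound 3 `O=C(Nc1cccc(-c2cccc(Cl)c2)c1)C(Cl)Cl` also shows only a limit, > 50000 nM. Compound 2 therefore offers no exact starting point, as it stands at the limit of > 50000 nM in this assay, at which 2 of the 3 values shown sit.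

Compound 4 `O=C(Nc1cccc(-c2ccoc2)c1)C(Cl)Cl` differs from compound 2 in one place, where furan-3-yl takes the place of thiophen-2-yl on an aromatic carbon: furan-3-yl in place of thiophen-2-yl on an aromatic carbon. Both groups are five-membered aromatic rings with 1 hetero atom. Among the measured compounds shown here, no measured step shows what such a swap does here. Resting on compound 2 and its limit of > 50000 nM, no change beyond the usual scatter is expected in this assay, and compound 4 may well report only the same limit. The expected change is a number no higher from compound 2 to compound 4 (the limit leaves the size open). For compound 4 the estimated value is 50000 nM, with an expected range from 20000 nM to 120000 nM.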

Compound 4, half-maximal inhibitory concentration: 37600 nM
The estimate for compound 4 lay 1.3-fold (0.12 log units) above the measured number; measured number inside the range.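

Compound 4 gives a true number in this assay, 37600 nM, so this place on the ring now has one exact reading for a five-membered aromatic ring with 1 hetero atom. Compound 2 shows only a limit of the assay, > 50000 nM. Furan-3-yl in place of thiophen-2-yl therefore gives an at least 1.3-fold lower number from compound 2 to compound 4 (0.12 log units; that floor lies within the scatter), and the real size of the step stays open because compound 2 offers no exact number: the limit of > 50000 nM in this assay, at which 2 of the 4 values shown sit.

This swap changes both the hetero atom and the point of attachment, so a thiophen-3-yl group at this place would be needed to tell those two changes apart. Also open, going by these compounds, is what an amine or a carboxylic acid would do on the same aromatic carbon.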